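Swapping a phenyl for pentylcarbonyl on an EP2 agonist

The compounds below may be only part of what the source reports. "The series", "measured", "known", "first", "only" and "open" are said of these compounds alone.

Measured compounds:
- compound 1, `CCCCc1ccc(CN(Cc2ccccc2OCC(=O)O)S(C)(=O)=O)cc1` — "not determined" (no result reported) in a functional assay on HEK293 cells for agonist activity at prostaglandin E2 receptor EP2 subtype (Rattus norvegicus), read by cAMP accumulation; on this read-out lower numbers stand for an effect already at smaller amounts and higher numbers for an effect only at larger amounts of compound
- compound 2, `CS(=O)(=O)N(CCCCCCC(=O)O)Cc1ccc(-c2ccccc2)cc1` — 457 nM
- compound 3, `Cn1ccnc1CS(=O)(=O)N(Cc1ccc(C(C)(C)C)cc1)Cc1cccc(OCC(=O)O)c1` — 58 nM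

Of the two compounds with a number in this assay, compound 2 stands highest, and compound 3 sits at a clearly lower number, a gap beyond the usual scatter. Compound 1 has no result. The unmeasured compound 4, `CCCCCC(=O)c1ccc(CN(CCCCCCC(=O)O)S(C)(=O)=O)cc1`, keeps the sulfonyl-linked chain ending in a carboxylic acid of compound 2 and changes only one spot: pentylcarbonyl in place of phenyl on an aromatic carbon. Without a measured step of this kind to lean on, the expectation rests on compound 2 alone. The change is expected to move the number by no more than a small step, as a 1.4-fold lower number from compound 2 to compound 4 (0.15 log units; within the scatter), either way within or near the scatter. Compound 4 is therefore estimated at 320 nM, in the range 80 nM to 1300 nM.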

Compound 4, half-maximal effective concentration: 887 nM
Estimate against measurement, compound 4: 2.8-fold (0.44 log units) below, and the stated range covers the measured number.
By their numbers in this assay, from the lowest: compound 3; then compounds 2 and 4 (each within the scatter of the next).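

In this assay the phenyl ring on this aromatic carbon, para to a large group, gives way to the open pentylcarbonyl chain with a step that stays within the scatter (a 1.9-fold higher number from compound 2 to compound 4 (0.29 log units; within the scatter)). For this pair, then, a group with no ring and one hydrogen-bond acceptor reads the same as an aromatic ring with none. No measurement at hand explains this result. From the compounds shown here alone, whether an amine or a longer chain on the same carbon would also stay within the scatter of compound 2 remains open. This single pair also cannot show whether the swap behaves alike on other cores.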